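Notes on the aryl group at the terminal position

A few compounds are considered here, and "the series" means these few. Any claim that something is new, unique, unknown or untested is made for them only; others in the source may bear on it.

Measured in a functional assay on MV4-11 cells (Homo sapiens) for antiproliferative activity, with a stated time of 6 days, tested at 1.56 uM; a higher number here means a stronger effect of the compound at the concentration tested, a lower number a weaker effect:
compound 1, `CNC(=O)N1CCCc2ccc(NC(=O)c3ccc(-c4ccncc4)cc3)cc21`, gives 37.6%
compound 2, `CNC(=O)N1CCCc2ccc(NC(=O)c3ccc(-c4ccn(C)n4)cc3)cc21`, gives 72.2%
compound 3, `CNC(=O)N1CCCc2ccc(NC(=O)c3ccc(-c4ccccc4)cc3)cc21`, gives 19.7%

Compound 3 stands lowest of the three in this assay; compound 1 is nearest, compound 2 furthest, both steps beyond the scatter. The three differ only in the aromatic group on the same carbon of the shared core: pyridin-4-yl, 1-methyl-1H-pyrazol-3-yl, phenyl.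

Compound 4, `CNC(=O)N1CCCc2ccc(NC(=O)c3ccc(-c4cnn(S(C)(=O)=O)c4)cc3)cc21`, is not yet measured. Change: 1-(methylsulfonyl)-1H-pyrazol-4-yl in place of phenyl on an aromatic carbon.

Within the data shown here, two measured steps bear on it, both leaving phenyl for a nitrogen-containing aromatic group: a number 17.9 percentage points lower from compound 1 to compound 3 (beyond the scatter) and a number 52.5 percentage points lower from compound 2 to compound 3 (beyond the scatter). Read in reverse, both point upward from compound 3, the step to the five-membered pyrazole being the larger one. Compound 4 also carries a five-membered ring with two nitrogens, though at a different attachment and with a methylsulfonyl rather than a methyl; with only three points the size is uncertain, but a rise beyond the scatter is expected for compound 4, a number 30.3 percentage points higher from compound 3 to compound 4 (beyond the scatter). The estimate for compound 4 is 50%, expected between 22% and 80%.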

Compound 4, a percentage reported as inhibition, at one concentration (the size of the read-out at that concentration, not a potency): 4.5%
Compound 4: middle estimate off by 45.5 percentage points, on the high side; the whole stated range lies above it.
By their numbers in this assay, from the lowest: compound 4; then compound 3; then compound 1; then compound 2.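

In this assay, a five-membered aromatic ring with 2 hetero atoms does not by itself lift the number at this position: the change from phenyl to 1-(methylsulfonyl)-1H-pyrazol-4-yl gives a number 15.2 percentage points lower from compound 3 to compound 4 (beyond the scatter) and puts this group under the carbon-only ring. The drop is larger against the other two groups, with a number 67.7 percentage points lower from compound 2 to compound 4 (beyond the scatter) and a number 33.1 percentage points lower from compound 1 to compound 4 (beyond the scatter) both on record, so the two pyrazole compounds now mark the two ends of the series and the ring type alone does not set the order. Nothing available on this series accounts for the drop.

From the compounds shown here alone, compound 2 and compound 4 differ at once in the ring attachment and in the group on the ring nitrogen, so it remains open which of the two carries the loss. A 1-methyl-1H-pyrazol-4-yl group would separate them, and an unsubstituted 1H-pyrazol-4-yl group would show the ring without either methyl or methylsulfonyl.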